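From cyclopentyl to cyclohexyl on an amide-type nitrogen

The compounds below may be only part of what the source reports. "The series", "measured", "known", "first", "only" and "open" are said of these compounds alone.

In a functional assay on T-24 cells (Homo sapiens) for antiproliferative activity, read by MTT assay, with a stated time of 48 h (a higher number here means a weaker inhibitor, a lower number a stronger inhibitor), compound 1 `COc1ccc(NC(=O)Nc2cccc(CNc3nccnc3Cl)c2)cc1` gives 9820 nM. Compound 2 `O=C(Nc1cccc(CNc2nccnc2Cl)c1)NC1CCCC1` gives > 40000 nM, which is a limit and not a number. Compound 3 `O=C(Nc1cccc(CNc2nccnc2Cl)c1)NC1CCCCC1` carries cyclohexyl in place of cyclopentyl on an amide-type nitrogen. For the measured compounds named here, the only measured step at this nitrogen, an at least 4.0-fold higher number from compound 1 to compound 2 (0.60 log units; beyond the scatter), lies beyond the scatter, but it replaces 4-methoxyphenyl and offers no direct comparison of two non-aromatic carbon rings. No change beyond the scatter is therefore expected in this assay, and the expected step is an at least 1.0-fold lower number from compound 2 to compound 3 (0.02 log units; that floor lies within the scatter). The estimate for compound 3 is 38000 nM, with an expected range of 18000 nM to 80000 nM.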

Compound 3, half-maximal inhibitory concentration: > 40000 nM
Compound 3 gave a limit, no number; the forecaster's own chance of this, stated with the estimate: 60%; at least 1.0-fold (0.02 log units) between middle value and limit.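

In this assay the drop from 4-methoxyphenyl now holds for a second non-aromatic carbon ring, with an at least 4.0-fold higher number from compound 1 to compound 3 (0.60 log units; beyond the scatter) for cyclohexyl in place of 4-methoxyphenyl on the amide-type nitrogen. Compound 2 and compound 3 both end at a limit of the assay and not at a number, so the step from cyclopentyl to cyclohexyl cannot be read: the limit of > 40000 nM in this assay, at which 2 of the 3 values shown sit. Still open, on these data alone, is whether a cyclohexyl ring carrying an amine or a carboxylic acid, or a longer chain on this nitrogen, would return a number under that limit.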